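The source may hold more compounds than are shown below. What is called first, only, known or untested is meant among the compounds shown, and "the series" means these compounds.

Measured so far:
compound 1, `Nc1ccc(S(=O)(=O)N2CCN(c3ncc(C(O)(C(F)(F)F)C(F)(F)F)cc3C#CC3CC3)CC2)cn1`: < 14 mL.min-1.g-1
compound 2, `CC(C)(C)n1cc(-c2cc(C(O)(C(F)(F)F)C(F)(F)F)cnc2N2CCN(S(=O)(=O)c3ccc(N)nc3)CC2)cn1`: 86 mL.min-1.g-1

Within the data shown here, in an ADME assay (liver) for metabolic stability, with Liver microsome (Homo sapiens) as the target, using microsomes and NADPH, with a stated time of 30 min, tested at 1 uM (on this read-out higher numbers stand for fast clearance and lower numbers for slow clearance), compound 2 gives 86 mL.min-1.g-1, the only measured number in the pair. For compound 1 this assay reports only a limit of the assay, not a number: the limit of < 14 mL.min-1.g-1 in this assay, at which 1 of the 2 values shown sits. Among the measured compounds shown here, the single measured step, an at least 6.1-fold higher number from compound 1 to compound 2 (0.78 log units; beyond the scatter), is therefore bounded on one side only, but it does show that the group on this aromatic carbon moves clearance, with compound 2 carrying the higher reading.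

Compound 3, `Nc1ccc(S(=O)(=O)N2CCN(c3ncc(C(O)(C(F)(F)F)C(F)(F)F)cc3-c3cncc(F)c3)CC2)cn1`, is not yet measured in this assay. Its change from compound 2 is 5-fluoropyridin-3-yl in place of 1-(tert-butyl)-1H-pyrazol-4-yl on an aromatic carbon. For the measured compounds named here, the change sits at the same aromatic carbon as the measured step, yet no measured pair compares 5-fluoropyridin-3-yl with anything, so the direction rests on the step of an at least 6.1-fold higher number from compound 1 to compound 2 (0.78 log units; beyond the scatter) alone, which places the 1-(tert-butyl)-1H-pyrazol-4-yl compound at the high end. A step back toward lower clearance, of modest size, is expected as a 2.2-fold lower number from compound 2 to compound 3 (0.33 log units; beyond the scatter). For compound 3 the value in this assay is estimated at 40 mL.min-1.g-1, with a range of 14 mL.min-1.g-1 to 110 mL.min-1.g-1.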

Compound 3, intrinsic clearance in microsomes: 24 mL.min-1.g-1
Compound 3: the middle estimate sits 1.7-fold (0.22 log units) above what was measured; the range from low to high includes it.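

In this assay, 5-fluoropyridin-3-yl in place of 1-(tert-butyl)-1H-pyrazol-4-yl gives a 3.6-fold lower number from compound 2 to compound 3 (0.55 log units; beyond the scatter), so an aromatic ring on this carbon does not in itself bring the high reading, and the choice between these two aromatic rings changes clearance. Against the 2-cyclopropylethynyl group, the step is an at least 1.7-fold higher number from compound 1 to compound 3 (0.23 log units; that floor lies within the scatter), so the data do not separate 5-fluoropyridin-3-yl from 2-cyclopropylethynyl on this read-out. Compound 1 has only a limit of the assay, which leaves this step open on one side: the limit of < 14 mL.min-1.g-1 in this assay, at which 1 of the 3 values shown sits.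

On these data alone, the step from compound 2 to compound 3 changes the ring type, the tert-butyl group and the fluorine together, so the share of each in the lower reading remains unknown. A 1-methyl-1H-pyrazol-4-yl group would test the tert-butyl group with the five-membered ring kept, and an unsubstituted pyridin-3-yl group would test the fluorine with the six-membered ring kept.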